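A few compounds are considered here, and "the series" means these few. Any claim that something is new, unique, unknown or untested is made for them only; others in the source may bear on it.

Measured compounds:
compound 1, `COc1cc(-c2ccnc3cc(-c4ccc5cc[nH]c5c4)nn23)cc(OC)c1OC`, 187 nM;
compound 2, `COc1cc(-c2ccnc3c(-c4ccc(C)cc4)cnn23)cc(OC)c1OC`, > 10000 nM;
compound 3, `Cc1ccc(-c2cc3nccc(-c4ccc(F)cc4)n3n2)cc1`, > 10000 nM.

Within the data shown here, in a functional assay on HCT-116 cells (Homo sapiens) for inhibition, read by CCK-8 assay, with a stated time of 48 h (a lower number here means a stronger inhibitor, a higher number a weaker inhibitor), compound 1 gives 187 nM, the only actual number among the three measured compounds. For compound 2 the value > 10000 nM is a limit of this assay, not a number. For compound 3 likewise > 10000 nM is a limit. This is the limit of > 10000 nM in this assay, at which 2 of the 3 values shown sit. Among the measured compounds shown here, no pair of measured compounds differs in a single place, so no measured step is available for guidance. Compound 4, `COc1cc(-c2ccnc3cc(-c4ccc5c(ccn5C)c4)nn23)cc(OC)c1OC`, differs from compound 1 in one place: 1-methyl-1H-indol-5-yl in place of 1H-indol-6-yl on an aromatic carbon. The change is expected to cost some potency, with the step from compound 1 to compound 4 estimated at a 2.7-fold higher number from compound 1 to compound 4 (0.43 log units; beyond the scatter). Compound 4 is therefore expected to give about 500 nM, within 120 nM to 3000 nM.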

Compound 4, half-maximal inhibitory concentration: 39 nM
Estimate against measurement, compound 4: 13-fold (1.11 log units) above; the whole stated range lies above it.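

In this assay putting 1-methyl-1H-indol-5-yl in place of 1H-indol-6-yl on this aromatic carbon gives a 4.8-fold lower number from compound 1 to compound 4 (0.68 log units; beyond the scatter) and so shows that potency at this place can still rise when the indole is changed. The hydrogen-bond donor of 1H-indol-6-yl is therefore not required for potency in compound 4. Nothing measured here explains the gain.

On these data alone, the step changes the methyl and the point of attachment together, so their shares remain open. 1H-indol-5-yl and 1-methyl-1H-indol-6-yl at this place would separate them.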